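This account rests on a few compounds, and the source may have more. Where it says the series, first, only, none or still open, it means among the compounds named here.

In an assay on Sf9 cells for inhibition of serine/threonine-protein kinase 4 (Homo sapiens), read by luminescence and ADP-Glo, with a stated time of 1 h, in the presence of a further agent that is not named here (on this read-out lower numbers stand for stronger inhibition and higher numbers for weaker inhibition), compound 2 `CNS(=O)(=O)c1ccc(Nc2ncc3c(n2)N(C)C(c2c(F)cccc2F)C(=O)N3C)cc1` gives 318 nM, the highest of the three numbers measured. Compound 1 `CN1C(=O)C(c2c(F)cccc2F)N(C)c2nc(Nc3ccc(S(N)(=O)=O)cc3)ncc21` gives 42 nM, and compound 3 `CN1C(=O)C(c2c(F)cccc2F)N(C)c2nc(Nc3ccc(S(=O)(=O)NCC4CC4)cc3)ncc21` gives 79 nM. The steps of a 7.6-fold higher number from compound 1 to compound 2 (0.88 log units; beyond the scatter), a 4.0-fold lower number from compound 2 to compound 3 (0.60 log units; beyond the scatter) and a 1.9-fold higher number from compound 1 to compound 3 (0.27 log units; within the scatter) all concern the substituent on the sulfonamide nitrogen. Compound 4 `CNS(=O)(=O)c1ccc(Nc2ncc3c(n2)N(C)C(c2ccccc2C)C(=O)N3C)cc1` differs from compound 2 in another place: 2-methylphenyl in place of 2,6-difluorophenyl on a saturated ring carbon. For the measured compounds named here, no measured step touches this saturated ring carbon, so none of them bears directly on the change, and the expectation rests on compound 2 alone. For compound 4 the expected step is a 1.3-fold higher number from compound 2 to compound 4 (0.10 log units; within the scatter), with no direction expected beyond the scatter. Compound 4 is therefore estimated at 400 nM, within a wide range from 100 nM to 1600 nM.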

Compound 4, half-maximal inhibitory concentration: 104 nM
Estimate against measurement, compound 4: 3.8-fold (0.59 log units) above; the measured number falls inside the stated range.
By their numbers in this assay, from the lowest: compounds 1, 3 and 4 (each within the scatter of the next, the first and the last beyond it); then compound 2.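

In this assay, for the compounds shown here, 2-methylphenyl in place of 2,6-difluorophenyl on the saturated ring carbon gives a 3.1-fold lower number from compound 2 to compound 4 (0.49 log units; beyond the scatter), so this position, which no earlier step touched, can move the number beyond the scatter. The 2,6-difluorophenyl group is thus not needed for inhibition at this level, at least with the methyl group on the sulfonamide nitrogen. No evidence here accounts for the shift.

From the compounds shown here alone, whether the change carries over to the sulfonamides of compound 1 and compound 3 remains open. So does how unsubstituted phenyl, 2-chlorophenyl or a pyridine ring would read at this position.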